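Trimming the 1-methylbutyl chain of compound 3

A few compounds are considered here, and "the series" means these few. Any claim that something is new, unique, unknown or untested is made for them only; others in the source may bear on it.

In an in vitro ADME assay on microsomes from liver (Homo sapiens) for metabolic stability, tested at 5 uM (on this read-out lower numbers stand for a shorter-lived compound and higher numbers for a longer-lived compound), compound 1 `CC(C)(C)CCn1nc(-c2cccs2)c(O)c(C2=NS(=O)(=O)c3cc(NS(C)(=O)=O)ccc3N2)c1=O` gives > 1 h as a limit of the assay. Compound 2 `CCC(C)CCn1nc(-c2cccs2)c(O)c(C2=NS(=O)(=O)c3cc(NS(C)(=O)=O)ccc3N2)c1=O` gives > 1 h as a limit too. Compound 3 `CCCC(C)n1nc(-c2cccs2)c(O)c(C2=NS(=O)(=O)c3cc(NS(C)(=O)=O)ccc3N2)c1=O` gives > 1 h and is likewise a limit. For the measured compounds named here, the series so far offers the limit of > 1 h in this assay, at which 3 of the 3 values shown sit, and no number.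

Compound 4 `CCC(C)n1nc(-c2cccs2)c(O)c(C2=NS(=O)(=O)c3cc(NS(C)(=O)=O)ccc3N2)c1=O` differs from compound 3 by one change (hydrogen in place of methyl on a saturated chain carbon, three bonds along the chain from an aromatic nitrogen) with 1-methylbutyl going to sec-butyl. The nearest measured changes are a step that the two limits leave unreadable from compound 1 to compound 3 and a step that the two limits leave unreadable from compound 2 to compound 3 and neither gives a size to carry over. What is expected in this assay is a step that the limit leaves unreadable from compound 3 to compound 4 and no step beyond the scatter in either direction. Compound 4 is estimated at 1.5 h (expected range 0.9 h to 3 h).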

Compound 4, half-life: > 1 h
Compound 4: only a limit was reported; the forecaster's own chance of this, stated with the estimate: 85%; the middle value does not contradict the limit.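

No step can be read from compound 4 to compound 1, compound 2 or compound 3, because all four values are limits: the limit of > 1 h in this assay, at which 4 of the 4 values shown sit.

On these data alone, the actual half-life of each compound in this assay remains open, as does whether any of these chain changes shifts it.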